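Methoxy for Methyl on the Aryl Ketone Ring

The source may hold more compounds than are shown below. What is called first, only, known or untested is meant among the compounds shown, and "the series" means these compounds.

Of the compounds shown here, three have been measured in a functional assay on cells (Erythrocyte, Rattus norvegicus) for inhibition, read by hemolysis, with a stated time of 1 h; on this read-out higher numbers stand for weaker inhibition and lower numbers for stronger inhibition. Compound 1, `COc1cc(OC)c(OC)cc1/C=C/C(=O)c1ccc(C)cc1`, gives 2.24 ug/mL in this assay. Compound 2, `COc1cc(OC)c(-c2cc(=O)c3ccc(O)cc3o2)cc1OC`, gives 2.15 ug/mL, and compound 3, `COc1cc(OC)c(-c2cc(=O)c3cc(Cl)ccc3o2)cc1OC`, gives 2.13 ug/mL. The number for compound 1 is the highest of the three, yet the gap to compound 2 and the gap to compound 3 both lie within the usual scatter of repeated measurements, so the three compounds cannot be told apart on these numbers: they behave alike in this assay.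

Compound 4, `COc1ccc(C(=O)/C=C/c2cc(OC)c(OC)cc2OC)cc1`, has not yet been measured. It differs from compound 1 in one place: methoxy in place of methyl on an aromatic carbon. The ring that carries this group is otherwise unchanged, as is the rest of the molecule.

For the measured compounds named here, no pair of measured compounds differing in only one place is available, so there is no direct guide to how much such a swap moves the number. Since compounds 1, 2 and 3 all sit close together, the working expectation is that compound 4 will stay in the same region, with a step from compound 1 to compound 4 of a 1.1-fold lower number from compound 1 to compound 4 (0.05 log units; within the scatter), not beyond the scatter. Compound 4 is therefore estimated at 2 ug/mL in this assay, with a range from 1 ug/mL to 4 ug/mL.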

Compound 4, half-maximal inhibitory concentration: 2.18 ug/mL
The estimate for compound 4 lay 1.1-fold (0.04 log units) below the measured number; the range from low to high includes it.
By their numbers in this assay, from the lowest: compounds 3, 2, 4 and 1 (each within the scatter of the next).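

In this assay the data now show a 1.0-fold lower number from compound 1 to compound 4 (0.01 log units; within the scatter) for the swap from 4-methylphenyl to 4-methoxyphenyl, and this is the first direct reading of a single change in the compounds shown. Until now, the close numbers came only from compounds that differ in more than one place, so they could not show what one group does at one position. At this position, on a six-membered aromatic ring of carbon only and para to a large group, methoxy can stand in place of methyl with no difference that this assay can separate from the usual scatter, and nothing available explains that outcome.

From the compounds shown here alone, this single swap says nothing about groups of a different kind, so it remains open whether an amine, a carboxylic acid or a longer chain at the same position would also leave the number within the scatter. Going by these compounds, it also remains open whether methoxy in place of methyl would give the same result elsewhere on this ring or on a different core.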